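The source may report more compounds than this note shows. Statements on the series, on what has been measured and on what is new or still open speak of the compounds shown alone.

Series notes on a functional assay on HT-29 cells (Homo sapiens) for cytotoxicity, read by MTT assay, with a stated time of 72 h; a higher number here means a weaker inhibitor, a lower number a stronger inhibitor:

- Compound 1, `CN1[C@@H]2c3[nH]c4ccccc4c3C[C@H]1[C@H](C#N)N1[C@@H](CNC(=O)c3ccc(F)cc3)c3[nH]c4ccccc4c3C[C@@H]21`: 1370 nM
- Compound 2, `CN1[C@@H]2c3[nH]c4ccccc4c3C[C@H]1[C@H](C#N)N1[C@@H](CNC(=O)c3ccc4ccccc4n3)c3[nH]c4ccccc4c3C[C@@H]21`: 150 nM
- Compound 3, `CN1[C@@H]2c3[nH]c4ccccc4c3C[C@H]1[C@H](C#N)N1[C@@H](CNC(=O)c3cc4ccccc4s3)c3[nH]c4ccccc4c3C[C@@H]21`: 640 nM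

Compound 3 stands second highest of the three numbers. Its nearest neighbour is compound 1, reached by a 2.1-fold lower number from compound 1 to compound 3 (0.33 log units; beyond the scatter); the furthest is compound 2, with a 4.3-fold higher number from compound 2 to compound 3 (0.63 log units; beyond the scatter). The remaining measured step, a 9.1-fold lower number from compound 1 to compound 2 (0.96 log units; beyond the scatter), is the widest spread among the amide groups so far.

Compound 4, `COc1ccc(/C=C/C(=O)NC[C@H]2c3[nH]c4ccccc4c3C[C@H]3[C@H]4c5[nH]c6ccccc6c5C[C@@H]([C@H](C#N)N23)N4C)cc1`, is not yet measured and differs from compound 3 in one place: 2-(4-methoxyphenyl)ethenyl in place of 1-benzothiophen-2-yl on a carbonyl carbon. The measured steps that bear on this change are the two in which the 1-benzothiophen-2-yl group takes part, a 2.1-fold lower number from compound 1 to compound 3 (0.33 log units; beyond the scatter) and a 4.3-fold higher number from compound 2 to compound 3 (0.63 log units; beyond the scatter); both are modest, and together they show that exchanging the group on the carbonyl carbon moves this assay by modest amounts, once down and once up. For the measured compounds named here, no measured step leads from a ring group to a 2-(4-methoxyphenyl)ethenyl group, so the direction for compound 4 is open. Without a precedent, a step of no more than modest size is expected, and a number not far from compound 3 is the most defensible guess. For compound 4 the expected step is a 1.4-fold higher number from compound 3 to compound 4 (0.15 log units; within the scatter). Compound 4 is therefore estimated at 900 nM in this assay, with a range from 300 nM to 2700 nM.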

Compound 4, half-maximal inhibitory concentration: 3060 nM
The estimate for compound 4 lay 3.4-fold (0.53 log units) below the measured number; measured number outside the range, above it.
By their numbers in this assay, from the lowest: compound 2; then compound 3; then compound 1; then compound 4.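

In this assay the 2-(4-methoxyphenyl)ethenyl group on the carbonyl carbon gives the weakest compound of the four, with a 4.8-fold higher number from compound 3 to compound 4 (0.68 log units; beyond the scatter) and a 2.2-fold higher number from compound 1 to compound 4 (0.35 log units; beyond the scatter) from the two nearer neighbours. For the compounds shown here, the change from quinolin-2-yl brings the first large step at this position, a 20-fold higher number from compound 2 to compound 4 (1.31 log units; beyond the scatter), so the span of this position in the assay is wider than the three ring groups alone suggested, and the group with a double bond outside aromatic rings lies at its high end while quinolin-2-yl holds the low end. The shown data offer no measurement that accounts for this rise in the number.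

The 2-(4-methoxyphenyl)ethenyl group differs from the ring groups in more than one feature, so the compounds shown do not separate the part played by the double bond from that of the methoxy group or of the ring itself. Going by these compounds, a plain 4-methoxyphenyl group on the carbonyl carbon, a 2-phenylethenyl group and a saturated 2-(4-methoxyphenyl)ethyl chain would each isolate one of these features, and whether a quinolin-2-yl group on an ethenyl chain keeps the low number remains open.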